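The source may hold more compounds than are shown below. What is called first, only, known or untested is meant among the compounds shown, and "the series" means these compounds.

Compound 1 `CCCCCNCc1c(O)ccc2ccc(=O)oc12`: in an assay on isolated protein for inhibition of seed linoleate 13S-lipoxygenase-1 (Glycine max) (a higher number here means a weaker inhibitor, a lower number a stronger inhibitor), compound 1 gives 59000 nM.
Compound 2 `CC(C)CNCc1c(O)ccc2ccc(=O)oc12`: in this assay compound 2 gives 47000 nM.
Compound 3 `CCCCCN(CCCCC)Cc1c(O)ccc2ccc(=O)oc12`: in this assay compound 3 gives 13000 nM.

Compound 1 has the highest number of the three; compound 2 sits nearest, and compound 3 furthest, with a 4.5-fold lower number from compound 1 to compound 3 (0.66 log units; beyond the scatter). Compound 4 `O=c1ccc2ccc(O)c(CNCc3ccccc3)c2o1` differs from compound 1 by phenyl in place of butyl on a saturated chain carbon bound to an amine nitrogen. The step that bears on this place is a 1.3-fold lower number from compound 1 to compound 2 (0.10 log units; within the scatter), a change at the same chain carbon that left the number essentially where it was. The larger step, a 4.5-fold lower number from compound 1 to compound 3 (0.66 log units; beyond the scatter), concerns the amine nitrogen itself and so does not speak to this change. The expectation is therefore a step of a 1.3-fold lower number from compound 1 to compound 4 (0.12 log units; within the scatter), not clearly beyond the scatter. Compound 4 is estimated at 45000 nM, within a range from 20000 nM to 120000 nM.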

Compound 4, half-maximal inhibitory concentration: 44000 nM
Beside the measured number, compound 4's estimate is 1.0-fold (0.01 log units) above it; the measured number falls inside the stated range.
By their numbers in this assay, from the lowest: compound 3; then compounds 4, 2 and 1 (each within the scatter of the next).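

In this assay, phenyl in place of butyl gives a 1.3-fold lower number from compound 1 to compound 4 (0.13 log units; within the scatter) and phenyl in place of isopropyl gives a 1.1-fold lower number from compound 2 to compound 4 (0.03 log units; within the scatter) so this chain carbon accepts an aromatic ring as readily as an open chain, with no clear gain or loss in inhibition. Nothing available explains this flat result.

The compounds shown leave open whether a phenyl ring carrying a methoxy group or a chlorine would move the number beyond the scatter. From the compounds shown here alone, a longer chain ending in phenyl also remains untested here.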